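Trimming the ester chain to a hydroxyethyl group

A few compounds are considered here, and "the series" means these few. Any claim that something is new, unique, unknown or untested is made for them only; others in the source may bear on it.

Compound 1 `CCCCn1nc(-c2cccnc2)c2ccccc2c1=O` gives 91%
Compound 2 `CCOC(=O)CCCn1nc(-c2cccnc2)c2ccccc2c1=O` gives 95%

For the measured compounds named here, in an assay on isolated protein (Oryctolagus cuniculus) with Thromboxane-A synthase (Homo sapiens) as the target, tested at 1 uM (a lower number here means less inhibition, a higher number more inhibition at the concentration tested (going by the name of the read-out)), compound 2 stands at 95%; the only other number, that of compound 1 at 91%, sits within the scatter of it, the step being a number 4 percentage points higher from compound 1 to compound 2 (within the scatter). Compound 3 `O=c1c2ccccc2c(-c2cccnc2)nn1CCO` differs from compound 2 by hydroxy in place of (ethoxycarbonyl)methyl on a saturated chain carbon, two bonds along the chain from an aromatic nitrogen. Going by the values given here, the one measured step, a number 4 percentage points higher from compound 1 to compound 2 (within the scatter), changed the same chain and stayed within the scatter, so no step beyond the scatter is expected here, the expected step being a number 5 percentage points lower from compound 2 to compound 3 (within the scatter). Compound 3 is therefore estimated at 90%, with a range from 75% to 97%.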

Compound 3, a percentage reported as inhibition, at one concentration (the size of the read-out at that concentration, not a potency): 69%
The estimate for compound 3 lay 21 percentage points above the measured number; the whole stated range lies above it.
By their numbers in this assay, from the lowest: compound 3; then compounds 1 and 2 (each within the scatter of the next).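

In this assay, this chain on the aromatic nitrogen can clearly change the read-out: hydroxy in place of (ethoxycarbonyl)methyl gives a number 26 percentage points lower from compound 2 to compound 3 (beyond the scatter), and hydroxy in place of ethyl gives a number 22 percentage points lower from compound 1 to compound 3 (beyond the scatter). The loss appears against both earlier chains, which lie within the scatter of each other. Nothing available accounts for this loss. The compounds shown leave open whether the hydroxy group or the shorter chain matters more, and a 4-hydroxybutyl chain, or an amine or carboxylic acid at the chain end, could help separate the two.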